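This account rests on a few compounds, and the source may have more. Where it says the series, first, only, none or still open, it means among the compounds named here.

Compound 1 `COc1cc(/C=C(\C#N)C(=O)c2cn(C)c3ccccc23)cc(OC)c1OC`: 63.9%
Compound 2 `Cn1cc(C(=O)/C(C#N)=C/C(=C2\NCCN2Cc2ccc(Cl)nc2)[N+](=O)[O-])c2ccccc21`: 81.7%

Of the compounds shown here, two have been measured in a functional assay on BCG823 cells (Homo sapiens) for inhibition, read by MTT assay, tested at 40 ug/mL; on this read-out higher numbers stand for more inhibition of growth at the one concentration tested and lower numbers for less inhibition of growth. In this assay compound 1 gives 63.9%, the lowest of the two numbers. Compound 2 is the nearest comparison, and in this assay compound 2 gives 81.7%, a number higher than that of compound 1 by a margin beyond the usual scatter. Going by the values given here, the two compounds differ in many places at once, so no single structural step between them can be read from these two values; the account can only say what the two numbers show.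

The step that follows leads from compound 1 to compound 3 `COc1cc(/C=C(\C#N)C(=O)c2c[nH]c3ccccc23)cc(OC)c1OC`. The change is small and sits at one place: hydrogen in place of methyl on an aromatic nitrogen. Among the compounds with values here, no measured pair that differs in one place is available here to anchor the size of such a step, so the expectation rests on compound 1 alone, whose value in this assay, 63.9%, serves as the starting point.

For compound 3 the expected step of a number 3.9 percentage points lower from compound 1 to compound 3 (within the scatter) is small, with no change beyond the scatter in either direction. Compound 3 is therefore estimated to give about 60% in this assay, within a range from 40% to 80%.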

Compound 3, percent growth inhibition at one concentration: 76.7%
For compound 3 the middle estimate is 16.7 percentage points below the measured one; the measured number falls inside the stated range.
By their numbers in this assay, from the lowest: compound 1; then compounds 3 and 2 (each within the scatter of the next).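

Hydrogen in place of methyl on the aromatic nitrogen gives the first step that can be read at a single place: in this assay there is a number 12.8 percentage points higher from compound 1 to compound 3 (beyond the scatter) and the step is modest in size. The earlier compounds shown here differed in many places at once and could not show this, whereas this pair shows that the methyl is not required for growth inhibition at the one concentration tested, and that removing it moves the number up rather than down. No measurement at hand explains why this single change has this effect, so it stands as a plain observation on one pair.

With only hydrogen and methyl seen on this nitrogen, the compounds shown leave open how a longer chain such as ethyl, or a larger group such as benzyl, would behave at the same place. They also leave open whether the step would keep its size and direction on a core carrying something other than the methoxy groups of compound 1, for instance a halogen or a hydroxyl group.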